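This account rests on a few compounds, and the source may have more. Where it says the series, first, only, none or still open, it means among the compounds named here.

Measured in a functional assay on HepG2 cells (Homo sapiens) for antiproliferative activity, read by MTT assay, with a stated time of 48 h; on this read-out higher numbers stand for weaker inhibition of growth and lower numbers for stronger inhibition of growth:
- compound 1 `COC(=O)N1N=C(c2cccc(O)c2)CC1c1cc(OC)c(OC)c(OC)c1`: 650 nM
- compound 2 `COC(=O)N1N=C(c2ccc(O)cc2)CC1c1cc(OC)c(OC)c(OC)c1`: 7820 nM

Of these two, compound 2 has the higher number, 7820 nM, and so the weaker inhibition of growth. Next is compound 3 `COC(=O)N1N=C(c2ccc(OC)c(OC)c2)CC1c1cc(OC)c(OC)c(OC)c1`, which has 3,4-dimethoxyphenyl in place of the 4-hydroxyphenyl of compound 2, on a carbon with a double bond to nitrogen: 3,4-dimethoxyphenyl in place of 4-hydroxyphenyl on a carbon with a double bond to nitrogen.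

Among the measured compounds shown here, only one measured step bears on this change: a 12-fold higher number from compound 1 to compound 2 (1.08 log units; beyond the scatter). That large step, beyond the scatter, came from exchanging 3-hydroxyphenyl for 4-hydroxyphenyl at this same place. For the measured compounds named here, no measured compound carries 3,4-dimethoxyphenyl, and none carries a methoxy group on this phenyl ring, so the guidance is indirect and the range must stay wide. The name of the entering group holds both ring numbers seen in the two hydroxyphenyl groups, so a number between the two measured values is expected in this assay.

The expected change is a moderate drop, smaller than the large step just described: a 3.1-fold lower number from compound 2 to compound 3 (0.50 log units; beyond the scatter). For compound 3 the estimated value is 2500 nM, with an expected range of 500 nM to 10000 nM.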

Compound 3, concentration for 50% growth inhibition: 4210 nM
Estimate against measurement, compound 3: 1.7-fold (0.23 log units) below; the measured number falls inside the stated range.
By their numbers in this assay, from the lowest: compound 1; then compounds 3 and 2 (each within the scatter of the next).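

In this assay, 3,4-dimethoxyphenyl in place of 4-hydroxyphenyl on the carbon with a double bond to nitrogen gives a 1.9-fold lower number from compound 2 to compound 3 (0.27 log units; within the scatter) and so does not separate the two groups, even though the entering group has 0 hydrogen-bond donors and the leaving group has 1. Set against 3-hydroxyphenyl at this same place, the same group gives a 6.5-fold higher number from compound 1 to compound 3 (0.81 log units; beyond the scatter) as a modest step beyond the scatter, so compound 1 now stands apart from both other compounds, not only from compound 2. No separate measurement bears on why these groups differ at this place.

Compound 1 is still the only member of the series with the lower number, and the compounds shown do not tell whether that number depends on the hydroxyl itself or on the ring position it occupies, since a single methoxy group or an amino group in place of that hydroxyl would be needed to separate the two. Also open, going by these compounds, is whether the methoxycarbonyl group on the ring nitrogen matters to this difference, for example whether a carboxylic acid or a longer ester chain there would keep the gap between the 3-hydroxyphenyl and 4-hydroxyphenyl compounds.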